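Adding Trifluoromethyl to Compound 3

This account rests on a few compounds, and the source may have more. Where it says the series, first, only, none or still open, it means among the compounds named here.

Compound 3 (`Clc1cc2nc(Cl)n(Cc3ccccc3)c2cc1Cl`) sits at > 100000 nM in a functional assay on KB cells (Homo sapiens) for inhibition (on this read-out lower numbers stand for stronger inhibition and higher numbers for weaker inhibition), as a limit of the assay and not a number. Compound 1 (`Nc1nc2cc(Cl)c(Cl)cc2n1Cc1ccccc1`) gives 170000 nM in this assay and differs by a single swap, chloro in place of amino, but a step that the limit leaves unreadable from compound 1 to compound 3 offers no size to work from. Among the compounds with values here, compound 4 (`FC(F)(F)c1ccc(Cn2c(Cl)nc3cc(Cl)c(Cl)cc32)cc1`) has not yet been measured, and its one change is this: trifluoromethyl in place of hydrogen on an aromatic carbon is the whole difference from compound 3. The nearest guide is compound 2 (`Nc1nc2cc(Cl)c(Cl)cc2n1Cc1cccc([N+](=O)[O-])c1`), which gives 65000 nM in this assay with nitro in place of hydrogen on an aromatic carbon. That change gives a 2.6-fold lower number from compound 1 to compound 2 (0.42 log units; beyond the scatter) on a different parent, so it is only a loose precedent. On that step, a modest move toward a lower number is expected for compound 4, though the result may again be only a limit. The expected change is an at least 1.6-fold lower number from compound 3 to compound 4 (0.22 log units; that floor lies within the scatter) in this assay on this estimate. Compound 4 is estimated at 60000 nM in this assay with an expected range from 20000 nM to 150000 nM as its likely span.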

Compound 4, half-maximal inhibitory concentration: > 100000 nM
Compound 4 ended at the assay's limit; the forecaster's own chance of this, stated with the estimate: 45%; at least 1.6-fold (0.22 log units) between middle value and limit.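

In this assay compound 4 gives > 100000 nM, a limit of the assay and not a number. Compound 3 gives > 100000 nM, also a limit, so no step between compound 3 and compound 4 can be read: the limit of > 100000 nM in this assay, at which 2 of the 4 values shown sit. The compounds shown leave open whether trifluoromethyl in place of hydrogen on an aromatic carbon shifts the read-out at all in this assay.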